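The source may report more compounds than this note shows. Statements on the series, on what has been measured and on what is new or still open speak of the compounds shown alone.

Three analogues on the shared core have so far been run in an assay on isolated protein for inhibition of protein kinase C theta type (Homo sapiens), read by TR-FRET, with a stated time of 2 h; on this read-out higher numbers stand for weaker inhibition and lower numbers for stronger inhibition. Compound 1 `CO[C@H]1CC[C@H](CNc2cc(NCc3cnccc3C(F)(F)F)ncc2C#N)CC1` gives 330 nM. Compound 2 `N#Cc1cnc(NCc2cnccc2C(F)(F)F)cc1N[C@H]1CC[C@@H](C(N)=O)CC1` gives 7 nM, and compound 3 `CC1(C)C[C@H](Nc2cc(NCc3cnccc3C(F)(F)F)ncc2C#N)CC[C@@H]1O` gives 7 nM. Both steps away from compound 1 are large: a 47-fold lower number from compound 1 to compound 2 (1.67 log units; beyond the scatter) and a 47-fold lower number from compound 1 to compound 3 (1.67 log units; beyond the scatter), whereas no change at the digits printed from compound 2 to compound 3 (within the scatter). Compound 3 therefore stands level with compound 2 at the low end of the three numbers and far from compound 1.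

Compound 4 `CC1(C)C[C@@H](Nc2cc(NCc3cnccc3C(F)(F)F)ncc2C#N)CC[C@@H]1O` keeps every atom and bond of compound 3 and differs only in configuration: the two compounds have the same atoms and bonds and differ only in configuration as drawn: 1 of 2 stereo elements differ; a stereocentre at a saturated ring carbon is drawn R in compound 3 and S in compound 4. For the measured compounds named here, none of the measured steps bears directly on this change; each of them exchanges one substituent for another on the amine nitrogen, and none inverts a stereocentre while leaving the skeleton unchanged. The size of this step is thus not set by any precedent in the series. Starting from compound 3 at 7 nM, a modest loss is expected, expressed as a 2.9-fold higher number from compound 3 to compound 4 (0.46 log units; beyond the scatter), with a wide spread on either side. Compound 4 is accordingly estimated at 20 nM, within 5 nM to 100 nM.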

Compound 4, half-maximal inhibitory concentration: 120 nM
Estimate against measurement, compound 4: 6.0-fold (0.78 log units) below, and the stated range ends below it.
By their numbers in this assay, from the lowest: compounds 2 and 3 (each within the scatter of the next); then compound 4; then compound 1.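

For the compounds shown here, the step of a 17-fold higher number from compound 3 to compound 4 (1.23 log units; beyond the scatter) is the first made by configuration alone, so the drawn sense at this saturated ring carbon is enough to move the number well beyond the scatter. In this assay, the 4-hydroxy-3,3-dimethylcyclohexyl group therefore does not secure a low number by its name alone: the S compound shows a 17-fold higher number from compound 2 to compound 4 (1.23 log units; beyond the scatter) and keeps only a 2.8-fold lower number from compound 1 to compound 4 (0.44 log units; beyond the scatter) as its gain. The loss can be placed on this one stereocentre because nothing else separates the pair: the fact that compounds 3 and 4 differ only in the configuration as drawn.

Open, from the compounds shown here alone, is whether inverting the other stereocentre, alone or together with this one, costs as much. Also open, going by these compounds, is whether an amine in place of the hydroxyl would show the same dependence on configuration at this ring carbon.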